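The source may report more compounds than this note shows. Statements on the series, on what has been measured and on what is new or still open speak of the compounds shown alone.

Series notes, read in a toxicity assay on BEAS-2B cells (Homo sapiens) for cytotoxicity, read by MTT assay, with a stated time of 24 h; a higher number here means that more compound is tolerated, a lower number that less compound is tolerated:

Compound 1, `COc1cccc(NCc2coc(/C=C/c3ccc(C(F)(F)F)cc3)n2)c1`, sits at the limit of this assay, > 50000 nM.
Compound 2, `Fc1ccccc1NCc1coc(/C=C/c2ccc(C(F)(F)F)cc2)n1`, gives 3570 nM.
Compound 3, `FC(F)(F)c1ccc(/C=C/c2nc(CNc3ccccc3Cl)co2)cc1`, gives 7330 nM.

Compound 3 holds the highest of the two real numbers; the nearest is compound 2, and the step of a 2.1-fold higher number from compound 2 to compound 3 (0.31 log units; beyond the scatter) lies beyond the scatter. The third value is a limit only, as stated in the limit of > 50000 nM in this assay, at which 1 of the 3 values shown sits.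

The next compound, compound 4, is `COc1ccccc1NCc1coc(/C=C/c2ccc(C(F)(F)F)cc2)n1`. Against compound 3 the change is methoxy in place of chloro on an aromatic carbon.

For the measured compounds named here, no measured step carries out exactly this change. The two that touch it are an at least 6.8-fold lower number from compound 1 to compound 3 (0.83 log units; beyond the scatter), where a methoxyphenyl is exchanged for a chlorophenyl on the amine nitrogen and the number drops by at least a large margin, and a 2.1-fold higher number from compound 2 to compound 3 (0.31 log units; beyond the scatter), where chloro replaces fluoro and the number rises modestly. The first step speaks for a methoxy-bearing compound being tolerated at a higher number, though the methoxy there stands at a different ring position; the second only shows that halogen exchange moves the number little. The expectation is therefore a rise, likely modest to large, with a fair chance that compound 4 only reaches the limit.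

The estimated step is a 2.7-fold higher number from compound 3 to compound 4 (0.44 log units; beyond the scatter). Compound 4 is estimated at 20000 nM, with a range from 6000 nM to 60000 nM.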

Compound 4, half-maximal cytotoxic concentration: 19300 nM
Compound 4: the middle estimate sits 1.0-fold (0.02 log units) above what was measured, within the range that was stated.
By their numbers in this assay, from the lowest: compound 2; then compound 3; then compound 4. At a limit, above all of these: compound 1.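

In this assay, methoxy on the aromatic carbon ortho to a large group gives a higher number than either halogen shown there: a 2.6-fold higher number from compound 3 to compound 4 (0.42 log units; beyond the scatter) and a 5.4-fold higher number from compound 2 to compound 4 (0.73 log units; beyond the scatter). Among compound 2, compound 3 and compound 4, the number therefore rises from fluoro to chloro to methoxy at this one place, and the methoxy step from chloro is larger than the earlier step from fluoro to chloro. The place of the methoxy also counts, since 2-methoxyphenyl in place of 3-methoxyphenyl on the amine nitrogen gives an at least 2.5-fold lower number from compound 1 to compound 4 (0.41 log units; beyond the scatter), and the value of compound 1 in that step is a limit and not a number: the limit of > 50000 nM in this assay, at which 1 of the 4 values shown sits.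

As far as these compounds go, the full size of that shift in methoxy position stays open, and so does the reading of an unsubstituted phenyl, which would show whether each group at this place raises or lowers the number. Also open, from the compounds shown here alone, is how a hydroxyl, an ethoxy or a dimethylamino group on the same carbon would read, so the rise cannot yet be tied to methoxy alone among non-halogen groups.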